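From methyl to pentyl in compound 2

This account rests on a few compounds, and the source may have more. Where it says the series, first, only, none or still open, it means among the compounds named here.

Measured in a functional assay on HCT-116 cells (Homo sapiens) for cytotoxicity, read by MTT assay, with a stated time of 72 h; a higher number here means that more compound is tolerated, a lower number that less compound is tolerated:
- compound 1 `COc1ccc2c(c1)c(O)c(C(=O)O)c(=O)n2C` gives > 10000 nM (a limit)
- compound 2 `Cn1c(=O)c(C(=O)O)c(O)c2cc(Cc3ccc(F)cc3)ccc21` gives > 10000 nM (a limit)

Compound 2 stands only at a limit, and no number is available for it. Both measured compounds sit at one shared ceiling (the limit of > 10000 nM in this assay, at which 2 of the 2 values shown sit). Compound 3 `CCCCCn1c(=O)c(C(=O)O)c(O)c2cc(Cc3ccc(F)cc3)ccc21` has butyl in place of hydrogen on a saturated chain carbon bound to an aromatic nitrogen. Within the data shown here, the only measured step (a step that the two limits leave unreadable from compound 1 to compound 2) lies at a different place and has no readable size. No step beyond the scatter is therefore expected in this assay, and the expected step is small (a number no higher from compound 2 to compound 3 (the limit leaves the size open)). Compound 3 is estimated at 10000 nM (expected range 3000 nM to 20000 nM).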

Compound 3, half-maximal cytotoxic concentration: > 10000 nM
Compound 3: a limit, no number (the forecaster's own chance of this, stated with the estimate: 70%); the middle value lies on the limit itself.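

No step can be read from compound 2 to compound 3 in this assay, as both stand only at a limit: the limit of > 10000 nM in this assay, at which 3 of the 3 values shown sit.

The compounds shown leave open whether methyl to pentyl changes the tolerated concentration at all; none of them gives a number.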